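Methyl for fluoro on the benzylic ring of compound 1

A few compounds are considered here, and "the series" means these few. Any claim that something is new, unique, unknown or untested is made for them only; others in the source may bear on it.

Two compounds of this series have a number in an assay on Sf9 cells for inhibition of Amine oxidase [flavin-containing] A (Homo sapiens), with stated times of 15 min and 60 min; a higher number here means a weaker inhibitor, a lower number a stronger inhibitor. Compound 1, `C#CCN(Cc1ccc(OCc2cccc(F)c2)cc1F)[C@@H](C)C(N)=O`, gives 8710 nM in this assay. Compound 2, `NC(=O)[C@@H]1CCCN1Cc1ccc(OCc2cccc(F)c2)cc1`, gives 34200 nM. Among the compounds with values here, of the two, compound 1 stands at the lower number, and its gap to compound 2 is beyond the usual scatter of the measurement; no single-point step between the two measured compounds is available, so the gap is only described by the two values themselves.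

The next compound is compound 3, `C#CCN(Cc1ccc(OCc2cccc(F)c2)cc1C)[C@@H](C)C(N)=O`. It differs from compound 1 by methyl in place of fluoro on an aromatic carbon. The change sits on an aromatic carbon of a six-membered aromatic ring of carbon only, ortho to a large group and meta to a group of 9 heavy atoms; no donor, acceptor or charge is added or removed. Within the data shown here, with no measured pair to show what such a swap does here, the expected step from compound 1 to compound 3 in this assay is a 1.0-fold lower number from compound 1 to compound 3 (0.01 log units; within the scatter), that is, no step beyond the scatter in either direction. Compound 3 is therefore estimated at 8500 nM in this assay, with a range of 3000 nM to 25000 nM.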

Compound 3, half-maximal inhibitory concentration: 6400 nM
Beside the measured number, compound 3's estimate is 1.3-fold (0.12 log units) above it, within the range that was stated.
By their numbers in this assay, from the lowest: compounds 3 and 1 (each within the scatter of the next); then compound 2.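

Within the data shown here, at the aromatic carbon ortho to a large group, methyl in place of fluoro gives a 1.4-fold lower number from compound 1 to compound 3 (0.13 log units; within the scatter), the first single-place step. In this assay, this position therefore carries either of these two single-atom groups with no step beyond the scatter, so compound 1 and compound 3 cannot be ranked against each other. No available evidence accounts for this result.

Still open is whether a different group on this aromatic carbon, such as chloro, methoxy, trifluoromethyl or an amine, or plain hydrogen, would move the number beyond the scatter; the two groups shown are each a single heavy atom and say little about anything larger. Also open is whether methyl in place of fluoro would give a similar step on a core changed elsewhere, for example with a carboxylic acid in place of the amide, since the one pair shown shares the core of compound 1 in every other place.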